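A few compounds are considered here, and "the series" means these few. Any claim that something is new, unique, unknown or untested is made for them only; others in the source may bear on it.

Within the data shown here, compound 2 `O=C1c2ccccc2C(=O)N1C[SeH]` is the one compound of this small set that carries a number in a functional assay on MCF7 cells (Homo sapiens) for cytotoxicity, read by MTT assay, with a stated time of 72 h (a higher number here means a weaker inhibitor of growth, a lower number a stronger inhibitor of growth), where compound 2 gives 8200 nM. Compound 1 `C[Se]c1ccc2ccccc2n1` reaches only a limit: in this assay compound 1 gives > 100000 nM, which is a limit rather than a number. Compound 2 thus stands as the sole measured point, the other value being a limit (the limit of > 100000 nM in this assay, at which 1 of the 2 values shown sits). Compound 3 `N#C[Se]CN1C(=O)c2ccccc2C1=O` has not yet been tested in this assay. It differs from compound 2 by cyano in place of hydrogen on a selenium. Among the measured compounds shown here, no step between measured compounds is available to calibrate such a change, so the expectation rests on compound 2 alone. The step of a 1.2-fold higher number from compound 2 to compound 3 (0.09 log units; within the scatter) is expected to be modest, possibly none beyond the scatter, with either direction open. Compound 3 is therefore estimated to give 10000 nM in this assay, within a range from 2500 nM to 40000 nM.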

Compound 3, concentration for total growth inhibition: 56100 nM
Estimate against measurement, compound 3: 5.6-fold (0.75 log units) below; the measured number lies above the stated range.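

On a selenium whose other neighbours are a saturated chain carbon, cyano in place of hydrogen gives, in this assay, a 6.8-fold higher number from compound 2 to compound 3 (0.84 log units; beyond the scatter), a change towards weaker inhibition of growth. Among these compounds, this is the first step that can be read in the set, and it shows that this position responds to substitution, which a single measured point could not show. Nothing measured here gives a cause for the step.

Whether the change in growth inhibition comes from the cyano itself or from the loss of the hydrogen on the selenium stays open, since only this one replacement is shown. On these data alone, it is also open how an amine or a longer chain on the same selenium would compare with compound 2 and compound 3.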